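Replacing the (ethoxycarbonyl)methyl group of compound 3

The compounds below may be only part of what the source reports. "The series", "measured", "known", "first", "only" and "open" are said of these compounds alone.

Compound 1 `COc1ccccc1OCC1SCCN1C(=O)CNC(C)=O`: 40 mg/kg
Compound 2 `COc1ccccc1OCC1SCCN1C(=O)Cn1ccnc1`: 50 mg/kg
Compound 3 `CCOC(=O)CCC(=O)N1CCSC1COc1ccccc1OC`: 24 mg/kg

These values come from a functional assay on the whole organism for inhibition, with Cavia porcellus as the target; on this read-out higher numbers stand for an effect only at larger amounts of compound and lower numbers for an effect already at smaller amounts. Compound 3 has the lowest number of the three, but it cannot be separated from compound 1, as the data show a 1.7-fold lower number from compound 1 to compound 3 (0.22 log units; within the scatter). Only its gap to compound 2 clears the scatter, with a 2.1-fold lower number from compound 2 to compound 3 (0.32 log units; beyond the scatter). Compound 4 `COc1ccccc1OCC1SCCN1C(=O)CC(=O)N1CCN(C)CC1` brings this change: (4-methylpiperazin-1-yl)carbonyl in place of (ethoxycarbonyl)methyl on a saturated chain carbon bound to a carbonyl carbon. Exchanges at this place have moved the number little, as seen in a 1.3-fold higher number from compound 1 to compound 2 (0.10 log units; within the scatter). The largest measured step is the modest one to compound 3. For the measured compounds named here, no compound yet carries the entering group, so no step beyond the scatter is expected in this assay, and the expected step is a 1.4-fold higher number from compound 3 to compound 4 (0.14 log units; within the scatter). For compound 4 the estimated value is 33 mg/kg, with an expected range of 14 mg/kg to 75 mg/kg.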

Compound 4, dose for half-maximal effect: 27 mg/kg
Compound 4: middle estimate off by 1.2-fold (0.09 log units), on the high side, and the stated range covers the measured number.
By their numbers in this assay, from the lowest: compounds 3, 4, 1 and 2 (each within the scatter of the next, the first and the last beyond it).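

A six-membered non-aromatic ring carried on a carbonyl at this place leaves the number unchanged in this assay, with a 1.1-fold higher number from compound 3 to compound 4 (0.05 log units; within the scatter). The other new steps also stay within the scatter, with a 1.5-fold lower number from compound 1 to compound 4 (0.17 log units; within the scatter) and a 1.9-fold lower number from compound 2 to compound 4 (0.27 log units; within the scatter), so the new group cannot be separated from any of the three earlier groups. Nothing measured here explains this tolerance.

On these data alone, it remains open whether a free carboxylic acid or a primary amine on this saturated chain carbon bound to a carbonyl carbon would shift the number beyond the scatter.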